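Replacing the aryl group on the sulfonamide nitrogen

The compounds below may be only part of what the source reports. "The series", "measured", "known", "first", "only" and "open" are said of these compounds alone.

The three measured compounds share one core and differ only in the aryl group on the sulfonamide nitrogen. Compound 1 `Cc1ccc(NS(=O)(=O)c2ccc(N3CCNC3=O)cc2)cc1C` gives 230 nM in a functional assay on MCF7 cells (Homo sapiens) for antiproliferative activity, read by sulforhodamine B assay, with a stated time of 48 h (on this read-out higher numbers stand for weaker inhibition and lower numbers for stronger inhibition), the highest number of the three. Compound 2 `O=C1NCCN1c1ccc(S(=O)(=O)Nc2cccc(Br)c2)cc1` gives 100 nM, and compound 3 `Cc1ccc(C)c(NS(=O)(=O)c2ccc(N3CCNC3=O)cc2)c1` gives 48 nM. The two measured steps away from compound 1 both point the same way: a 2.3-fold lower number from compound 1 to compound 2 (0.36 log units; beyond the scatter) and a 4.8-fold lower number from compound 1 to compound 3 (0.68 log units; beyond the scatter). Between them, a 2.1-fold lower number from compound 2 to compound 3 (0.32 log units; beyond the scatter).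

Compound 4 `COc1ccc(NS(=O)(=O)c2ccc(N3CCNC3=O)cc2)cc1` carries a change at the same place, (4-methoxyphenyl in place of 3,4-dimethylphenyl on a sulfonamide nitrogen). Neither measured step tests a group with a hydrogen-bond acceptor there, so they bear on it only loosely; both, however, were modest and lowered the number, and compound 1 sits at the top of the range. She therefore expects a small step, most likely toward a lower number, of a size near the scatter rather than clearly beyond it.

Compound 4 is estimated at 160 nM, within a range from 60 nM to 450 nM, which would mean an expected step of a 1.4-fold lower number from compound 1 to compound 4 (0.16 log units; within the scatter).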

Compound 4, half-maximal inhibitory concentration: > 1000 nM
Compound 4: a limit, no number (the forecaster's own chance of this, stated with the estimate: 3%); at least 6.2-fold (0.79 log units) between middle value and limit.
By their numbers in this assay, from the lowest: compound 3; then compound 2; then compound 1. At a limit, above all of these: compound 4.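

Going by these compounds alone, compound 4 is the first change at this position that raises the number, an at least 4.3-fold higher number from compound 1 to compound 4 (0.63 log units; beyond the scatter), although the swap keeps the count at 8 heavy atoms and adds a hydrogen-bond acceptor. The gap is wider against the other two aryl groups, an at least 10-fold higher number from compound 2 to compound 4 (1.00 log units; beyond the scatter) and an at least 20-fold higher number from compound 3 to compound 4 (1.31 log units; beyond the scatter), which shows that the aryl group on the sulfonamide nitrogen can shift this read-out well beyond the modest steps among compounds 1, 2 and 3. The value of compound 4 in this assay is a limit and not a number: the limit of > 1000 nM in this assay, at which 1 of the 4 values shown sits.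

On these data alone, whether the rise belongs to the methoxy group itself or to where it sits stays open, and a 3-methoxyphenyl or a 4-methylphenyl group would separate the two. As far as these compounds go, how an aryl group carrying an amine or a carboxylic acid would read also remains open.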